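A few compounds are considered here, and "the series" means these few. Any claim that something is new, unique, unknown or untested is made for them only; others in the source may bear on it.

In an assay on microsomes from intestine for inhibition of acyl-CoA:cholesterol acyltransferase (Oryctolagus cuniculus) (on this read-out higher numbers stand for weaker inhibition and lower numbers for stronger inhibition), three compounds have been measured. Compound 1 `CCCCN1NN=C(NC(=O)Nc2c(C(C)C)cccc2C(C)C)N1` gives 92 nM. Compound 2 `CCCCCCN1NN=C(NC(=O)Nc2c(C(C)C)cccc2C(C)C)N1` gives in this assay 73 nM. The change from compound 1 to compound 2 is ethyl in place of hydrogen on a saturated chain carbon, four bonds along the chain from an amine nitrogen in a ring, and the step it made was a 1.3-fold lower number from compound 1 to compound 2 (0.10 log units; within the scatter). Compound 3 `CCCCCCCCCCn1nnnc1NC(=O)Nc1c(C(C)C)cccc1C(C)C` is built on a different core, and the difference between the two cores is not broken down here. In this assay compound 3 gives 180 nM. The gap between the values of compound 3 and compound 1 is within the scatter, while the gap between compound 3 and compound 2 lies beyond it.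

Compound 4 `CCCCCCCCCCCCn1nnnc1NC(=O)Nc1c(C(C)C)cccc1C(C)C` has not been measured. It differs from compound 3 by ethyl in place of hydrogen on a saturated chain carbon, ten or more bonds along the chain from an aromatic nitrogen. This is the same kind of change as that from compound 1 to compound 2, though not the same: the place on the chain differs, as the two counted differences show, and the cores differ. Because the earlier step was a 1.3-fold lower number from compound 1 to compound 2 (0.10 log units; within the scatter), the step expected from compound 3 to compound 4 is a 1.3-fold lower number from compound 3 to compound 4 (0.11 log units; within the scatter), resting on that single step on the other core and on nothing else. In this assay compound 4 is estimated at 140 nM, most likely between 70 nM and 280 nM.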

Compound 4, half-maximal inhibitory concentration: 210 nM
Estimate against measurement, compound 4: 1.5-fold (0.18 log units) below; the measured number falls inside the stated range.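

In this assay the ethyl in place of hydrogen on the core of compound 3 gave a 1.2-fold higher number from compound 3 to compound 4 (0.07 log units; within the scatter), so on this core, as on the core of compound 1, the change left the number within the usual scatter. Set side by side, the two steps cannot be told apart, and the change carries from one core to the other as a step too small to read: the same change on two cores in this assay, a 1.3-fold lower number (0.10 log units; within the scatter) from compound 1 to compound 2 and a 1.2-fold higher number (0.07 log units; within the scatter) from compound 3 to compound 4, 1.5-fold (0.17 log units) apart, within the scatter of two such steps

This does not show that the change has a shared direction, since the two steps point opposite ways inside the scatter, and it does not show that the change would act alike elsewhere, as each core offers a single pair and the change sits at a different place on the chain in each. The agreement therefore holds only for these two small steps and sets no rule for the series.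

The compounds shown leave open whether a shorter chain or a still longer chain would produce a step beyond the scatter on either core. They also leave open how the chain of compound 4 would read on the core of compound 1, and what a chain carrying an amine or a carboxylic acid would give.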